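Dropping the Benzyl Group From Two Related Cores

A few compounds are considered here, and "the series" means these few. Any claim that something is new, unique, unknown or untested is made for them only; others in the source may bear on it.

Measured in a functional assay on T47D cells (Homo sapiens) for antiproliferative activity, read by MTT assay, with a stated time of 48 h; on this read-out higher numbers stand for weaker inhibition and lower numbers for stronger inhibition:
Compound 1 `Brc1ccc2[nH]c(-c3cc4ccccc4n3Cc3ccccc3)nc2c1` gives 15500 nM
Compound 2 `Clc1cc2nc(-c3cc4ccccc4n3Cc3ccccc3)[nH]c2cc1Cl` gives 22500 nM
Compound 3 `Brc1ccc2[nH]c(-c3cc4ccccc4[nH]3)nc2c1` gives 4990 nM

Compound 1 and compound 2 lie within the scatter of one another, and the difference between their two cores is not broken down here. Compound 3 is made from compound 1 by one change, (hydrogen in place of benzyl on an aromatic nitrogen), and that change gave a 3.1-fold lower number from compound 1 to compound 3 (0.49 log units; beyond the scatter).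

Compound 4 `Clc1cc2nc(-c3cc4ccccc4[nH]3)[nH]c2cc1Cl` is made from compound 2 by the same change, (hydrogen in place of benzyl on an aromatic nitrogen). Because the earlier step of a 3.1-fold lower number from compound 1 to compound 3 (0.49 log units; beyond the scatter) went beyond the scatter, compound 4 is expected to show a step of similar size, a 3.1-fold lower number from compound 2 to compound 4 (0.49 log units; beyond the scatter). On this basis compound 4 is estimated to give about 7300 nM in this assay, with a plausible range from 3200 nM to 17000 nM; this rests on a single earlier step and is an expectation only.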

Compound 4, half-maximal inhibitory concentration: 21200 nM
For compound 4 the middle estimate is 2.9-fold (0.46 log units) below the measured one, outside the stated range (above it).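

In this assay, hydrogen in place of benzyl on an aromatic nitrogen gives, on the core of compound 2, a 1.1-fold lower number from compound 2 to compound 4 (0.03 log units; within the scatter). The change therefore does not carry over in size from one core to the other: the same change on two cores in this assay, a 3.1-fold lower number (0.49 log units; beyond the scatter) from compound 1 to compound 3 and a 1.1-fold lower number (0.03 log units; within the scatter) from compound 2 to compound 4, 2.9-fold (0.47 log units) apart, beyond the scatter of two such steps. This shows that the step cannot be assumed to transfer between these two cores, but two pairs do not show which difference between the cores matters, or how the change would behave on any further core.

Going by these compounds, it remains open what a methyl group, or a longer chain ending in an amine, would give on that aromatic nitrogen. On these data alone, it also remains open whether either group would give different steps on the two cores.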